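This account rests on a few compounds, and the source may have more. Where it says the series, first, only, none or still open, it means among the compounds named here.

In a functional assay on COR-L23 cells (Homo sapiens) for antiproliferative activity, read by CellTiter-Glo, with a stated time of 4 days (on this read-out lower numbers stand for stronger inhibition and higher numbers for weaker inhibition), compound 1 `CCC(=O)NCc1ccc(NC(=O)[C@H]2C[C@@H]2c2cccnc2)cc1` gives > 2500 nM, which is a limit of the assay. Compound 2 `CCC(=O)N[C@@H](C)c1ccc(NC(=O)[C@H]2C[C@@H]2c2cccnc2)cc1` gives 22 nM, a large change, an at least 110-fold lower number from compound 1 to compound 2 (2.05 log units; beyond the scatter). Compound 3 `COCC(=O)N[C@@H](C)c1ccc(NC(=O)[C@H]2C[C@@H]2c2cccnc2)cc1` gives 111 nM, the higher of the two numbers that are not limits. Compound 4 `C[C@H](NC(=O)c1ccc(F)cc1)c1ccc(NC(=O)[C@H]2C[C@@H]2c2cccnc2)cc1` differs from it by 4-fluorophenyl in place of methoxymethyl on a carbonyl carbon, with 4-fluorophenyl in place of methoxymethyl on a carbonyl carbon. For the measured compounds named here, the only measured change in this part of the structure is modest, a 5.0-fold higher number from compound 2 to compound 3 (0.70 log units; beyond the scatter), and it points to a lower number once the methoxy is gone. No aromatic group has been measured here, so a modest step towards stronger inhibition is expected, a 2.8-fold lower number from compound 3 to compound 4 (0.44 log units; beyond the scatter). Compound 4 is estimated at 40 nM, with an expected range of 8 nM to 200 nM.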

Compound 4, half-maximal inhibitory concentration: 12 nM
Beside the measured number, compound 4's estimate is 3.3-fold (0.52 log units) above it; the range from low to high includes it.
By their numbers in this assay, from the lowest: compounds 4 and 2 (each within the scatter of the next); then compound 3. At a limit, above all of these: compound 1.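

Compound 4 shows that this carbonyl carbon accepts an aromatic ring as well as a small open chain: 4-fluorophenyl in place of methoxymethyl gives a 9.3-fold lower number from compound 3 to compound 4 (0.97 log units; beyond the scatter), while 4-fluorophenyl in place of ethyl gives a 1.8-fold lower number from compound 2 to compound 4 (0.26 log units; within the scatter). The ethyl and 4-fluorophenyl amides therefore cannot be told apart on these numbers. Nothing measured here gives a cause for either step. The compounds shown leave open whether plain phenyl, a pyridine ring or a chain carrying an amine would hold this level at the same carbonyl carbon. Also open, going by these compounds, is how 4-fluorophenyl behaves without the methyl on the chain carbon.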